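The compounds below may be only part of what the source reports. "The series", "measured", "known", "first", "only" and "open" are said of these compounds alone.

Measured compounds:
compound 1, `COC[C@H]1CN(c2ccn(C)c2)C(=O)O1`: 300 nM
compound 2, `CCn1ccc(N2C[C@H](COC)OC2=O)c1`: 0.6 nM
compound 3, `Cn1ccc(N2C[C@H](CN)OC2=O)c1`: 10 nM

Of the compounds shown here, three have been measured in an assay for inhibition of Amine oxidase [flavin-containing] A (Bos taurus), read by fluorescence, with a stated time of 30 min (on this read-out lower numbers stand for stronger inhibition and higher numbers for weaker inhibition), and a fourth, compound 4 with the structure `CCn1ccc(N2C[C@H](CN)OC2=O)c1`, is still to be tested. Compound 1 is the weakest of the three measured, and a single change, (methyl in place of hydrogen on a saturated chain carbon bound to an aromatic nitrogen), gives a 500-fold lower number from compound 1 to compound 2 (2.70 log units; beyond the scatter). A different change on the core of compound 1, (amino in place of methoxy on a saturated chain carbon bound to a saturated ring carbon), gives a 30-fold lower number from compound 1 to compound 3 (1.48 log units; beyond the scatter) and so yields the core of compound 3.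

Compound 4 is made from compound 3 by methyl in place of hydrogen on a saturated chain carbon bound to an aromatic nitrogen. This is the same change that was made from compound 1 to compound 2; the two cores differ by the change already described from compound 1 to compound 3. Going by the values given here, the one measured instance of this change was large, and the change is at the same place in both pairs. Nevertheless only one instance is available, and the starting point in compound 3 is already far lower than in compound 1, so the same size need not recur. Among the compounds with values here, compound 4 is therefore expected to show a step of a 100-fold lower number from compound 3 to compound 4 (2.00 log units; beyond the scatter), large but more cautious than the first, because that rests on the single step of a 500-fold lower number from compound 1 to compound 2 (2.70 log units; beyond the scatter). The estimated value for compound 4 in this assay is 0.1 nM, with a range from 0.01 nM to 1.5 nM.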

Compound 4, inhibition constant: 130 nM
For compound 4 the middle estimate is 1300-fold (3.11 log units) below the measured one; measured number above the stated range.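

In this assay, methyl in place of hydrogen on a saturated chain carbon bound to an aromatic nitrogen gives a 13-fold higher number from compound 3 to compound 4 (1.11 log units; beyond the scatter), so on the amino core the change does not repeat what it did on the methoxy core, and its direction reverses: the same change on two cores in this assay, a 500-fold lower number (2.70 log units; beyond the scatter) from compound 1 to compound 2 and a 13-fold higher number (1.11 log units; beyond the scatter) from compound 3 to compound 4, 6500-fold (3.81 log units) apart, beyond the scatter of two such steps
Seen from the other side, amino in place of methoxy on a saturated chain carbon bound to a saturated ring carbon gives a 220-fold higher number from compound 2 to compound 4 (2.34 log units; beyond the scatter), although the same change lowered the number on the core of compound 1: the same change on two cores in this assay, a 30-fold lower number (1.48 log units; beyond the scatter) from compound 1 to compound 3 and a 220-fold higher number (2.34 log units; beyond the scatter) from compound 2 to compound 4, 6500-fold (3.81 log units) apart, beyond the scatter of two such steps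
Going by these compounds alone, these four compounds show that the two changes do not add up here, but they do not show why, and with only two instances of each change they say nothing about how either would behave on a further core.

As far as these compounds go, it remains open whether the reversal is particular to the amino group or would also appear with a hydroxyl or a carboxylic acid on that chain carbon. From the compounds shown here alone, it is equally open whether a propyl chain in place of the ethyl would follow compound 2 or compound 4.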